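Methoxy for methylsulfanyl on the aryl ring: series notes

A few compounds are considered here, and "the series" means these few. Any claim that something is new, unique, unknown or untested is made for them only; others in the source may bear on it.

Measured compounds in an assay on HEK293 cells for displacement of a labelled ligand from 5-hydroxytryptamine receptor 7 (Rattus norvegicus); a lower number here means a stronger inhibitor, a higher number a weaker inhibitor:
compound 1 `CSc1ccccc1N1CCN(CCCCCC(=O)N2CCc3ccccc3C2)CC1` gives 32.9 nM
compound 2 `CSc1ccccc1N1CCN(CCCCCC(=O)NCc2ccccc2)CC1` gives 22 nM

Going by the values given here, compound 2 stands nearest compound 1 on the two numbers in hand; the only measured step, a 1.5-fold lower number from compound 1 to compound 2 (0.17 log units; within the scatter), exchanges the amide end of the shared core and lies within the scatter. Compound 3 `COc1ccccc1N1CCN(CCCCCC(=O)NCc2ccccc2)CC1` differs from compound 2 at the other end: methoxy in place of methylsulfanyl on an aromatic carbon. Among the compounds with values here, no measured step touches this aromatic position, so the step at the amide end says nothing about it; the data give no basis for expecting a change beyond the scatter in this assay in either direction. Compound 3 is therefore expected to land close to compound 2, at an estimated 20 nM with a range of 6 nM to 65 nM, the expected step being a 1.1-fold lower number from compound 2 to compound 3 (0.04 log units; within the scatter).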

Compound 3, inhibition constant: 224 nM
The estimate for compound 3 lay 11-fold (1.05 log units) below the measured number, outside the stated range (above it).
By their numbers in this assay, from the lowest: compounds 2 and 1 (each within the scatter of the next); then compound 3.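

In this assay, the aromatic carbon ortho to a large group proves sensitive to a change that the amide end did not foreshadow: 2-methoxyphenyl in place of 2-(methylsulfanyl)phenyl gives a 10-fold higher number from compound 2 to compound 3 (1.01 log units; beyond the scatter) while the exchange at the amide end gave only a 1.5-fold lower number from compound 1 to compound 2 (0.17 log units; within the scatter) in the same series. Methylsulfanyl and methoxy have the same counts of heavy atoms, hydrogen-bond donors and hydrogen-bond acceptors, so these counts do not account for the separation of the two compounds. No measurement here speaks to the origin of this large step.

On these data alone, it remains open whether methoxy costs as much when paired with the 1,2,3,4-tetrahydroisoquinolin-2-yl amide of compound 1. Also open, as far as these compounds go, is how ethylsulfanyl, chlorine or an amine at this aromatic carbon would compare, and whether a longer chain would change the picture.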